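Benzyl for (pyrrolidin-1-yl)sulfonyl: outlook for compound 4

The compounds below may be only part of what the source reports. "The series", "measured", "known", "first", "only" and "open" are said of these compounds alone.

Compound 3 `O=C(Nc1cccc(S(=O)(=O)N2CCCC2)c1)C1CCCN(C(=O)c2cc(C(F)(F)F)cc(C(F)(F)F)c2)C1` carries the shared core of the series with a (pyrrolidin-1-yl)sulfonyl group on the aromatic carbon. In a functional assay on PC-3 cells (Homo sapiens), with a stated time of 24 h, tested at 10 uM (a higher number here means more inhibition at the concentration tested (going by the name of the read-out), a lower number less inhibition), compound 3 gives < 30%, which is a limit of the assay and not a number. Compound 1 `O=C(Nc1cccc(OCCc2ccccn2)c1)C1CCCN(C(=O)c2cc(C(F)(F)F)cc(C(F)(F)F)c2)C1` gives in this assay the value < 30%, again a limit. Compound 2 `O=C(Nc1cccc(Oc2ccccc2)c1)C1CCCN(C(=O)c2cc(C(F)(F)F)cc(C(F)(F)F)c2)C1` gives in this assay the value < 30%, also a limit. Compound 3 therefore stands where the whole measured set stands: the limit of < 30% in this assay, at which 3 of the 3 values shown sit.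

The unmeasured compound 4 `O=C(Nc1cccc(Cc2ccccc2)c1)C1CCCN(C(=O)c2cc(C(F)(F)F)cc(C(F)(F)F)c2)C1` differs from compound 3 as follows: benzyl in place of (pyrrolidin-1-yl)sulfonyl on an aromatic carbon. The measured steps at this aromatic carbon are a step that the two limits leave unreadable from compound 1 to compound 3, a step that the two limits leave unreadable from compound 2 to compound 3 and a step that the two limits leave unreadable from compound 1 to compound 2; none of them has a readable size, since every value sits at the limit. Neither an ether-linked nor a sulfonyl-linked group at this carbon lifted inhibition above the limit, and nothing in the set suggests that a benzyl group would behave differently.

Compound 4 is therefore expected to give 15%, with a range of 0% to 35%, most likely reported again as a limit. The expected step is a step that the limit leaves unreadable from compound 3 to compound 4, no change beyond the scatter.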

Compound 4, a percentage reported as inhibition, at one concentration (the size of the read-out at that concentration, not a potency): < 30%
Compound 4: a limit, no number (the forecaster's own chance of this, stated with the estimate: 80%); the middle value does not contradict the limit.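

In this assay compound 4 gives < 30%, which is a limit of the assay and not a number. No step from compound 1, compound 2 or compound 3 to compound 4 can be read, as all of these compounds sit at the same limit: the limit of < 30% in this assay, at which 4 of the 4 values shown sit.

The compounds shown leave open how far these four compounds differ in this assay, and whether any group on this aromatic carbon gives a readable value.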